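A few compounds are considered here, and "the series" means these few. Any claim that something is new, unique, unknown or untested is made for them only; others in the source may bear on it.

Compound 2, whose structure is `COc1ccc(/C=C\c2cc(OC)c(OC)c(OC)c2)cc1OCc1ccc(CN[C@H](C(=O)O)[C@H](C)O)cc1`, sits at a limit rather than at a measured number in an ADME assay on HEK293 cells (Homo sapiens) for cytotoxicity, read by CCK-8 assay, with a stated time of 48 h (on this read-out lower numbers stand for stronger inhibition and higher numbers for weaker inhibition), where compound 2 gives > 50000 nM. The two neighbours it can be set against are no different in kind. Compound 1, with the structure `COc1ccc(/C=C\c2cc(OC)c(OC)c(OC)c2)cc1OCc1ccc(CN2CC[C@H](C(=O)O)C2)cc1`, reaches only a limit in this assay, giving > 50000 nM. Compound 3, with the structure `COc1ccc(/C=C\c2cc(OC)c(OC)c(OC)c2)cc1OCc1ccc(CNCCO)cc1`, likewise ends at a limit in this assay, giving > 50000 nM. The steps between these three compounds therefore cannot be read: from compound 1 to compound 2 the change is a step that the two limits leave unreadable from compound 1 to compound 2, from compound 1 to compound 3 it is a step that the two limits leave unreadable from compound 1 to compound 3, and from compound 2 to compound 3 it is a step that the two limits leave unreadable from compound 2 to compound 3. All that can be said is the limit of > 50000 nM in this assay, at which 3 of the 3 values shown sit.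

Compound 4, whose structure is `COc1ccc(/C=C\c2cc(OC)c(OC)c(OC)c2)cc1OCc1ccc(CNCCN(C)C)cc1`, is the compound still to be measured. It differs from compound 2 in one place: 2-(dimethylamino)ethyl in place of 1-carboxy-2-hydroxypropyl on an amine nitrogen. Among the measured compounds shown here, none of the measured steps gives a readable size for a change on this amine nitrogen, so no direction can be expected beyond a further limit. The step from compound 2 to compound 4 is estimated as a number no higher from compound 2 to compound 4 (the limit leaves the size open). For compound 4 the value expected in this assay is 50000 nM, within a range from 20000 nM to 120000 nM.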

Compound 4, half-maximal inhibitory concentration: 39000 nM
Compound 4: the middle estimate sits 1.3-fold (0.11 log units) above what was measured, and the stated range covers the measured number.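

In this assay, among the compounds shown here, compound 4 gives 39000 nM, the only number in this set that is not a limit. A change on this amine nitrogen can now be given a size, though only as a floor. Setting 2-(dimethylamino)ethyl in place of 1-carboxy-2-hydroxypropyl gives an at least 1.2-fold lower number from compound 2 to compound 4 (0.10 log units; that floor lies within the scatter), dimethylamino in place of hydroxy on the saturated chain carbon gives an at least 1.2-fold lower number from compound 3 to compound 4 (0.10 log units; that floor lies within the scatter), and (2-(dimethylamino)ethyl)amino in place of 3-carboxypyrrolidin-1-yl gives an at least 1.2-fold lower number from compound 1 to compound 4 (0.10 log units; that floor lies within the scatter). Each floor lies within the scatter, so none of these steps yet shows a real change, and the steps among compounds 1, 2 and 3 still cannot be read, all of them resting on a single bound: the limit of > 50000 nM in this assay, at which 3 of the 4 values shown sit.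

On these data alone, the true size of the three new steps stays open, since the number behind each limit is unknown and could lie close to that of compound 4 or far from it. Also open, as far as these compounds go, is what a longer chain carrying the dimethylamino group, or a primary amine in its place, would give on this amine nitrogen in this assay.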